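Trimming the Chain-End Nitrogen Group in Sigma-1 Binders

The source may report more compounds than this note shows. Statements on the series, on what has been measured and on what is new or still open speak of the compounds shown alone.

Three compounds have been measured in an assay on isolated protein (Cavia porcellus) with Sigma non-opioid intracellular receptor 1 (Homo sapiens) as the target, read by radioligand binding; on this read-out lower numbers stand for stronger inhibition and higher numbers for weaker inhibition:
- compound 1 `O=c1cc(-c2ccccc2)oc2ccc(OCCCCCCN3CCC(O)CC3)cc12` gives 100 nM
- compound 2 `O=c1cc(-c2ccccc2)oc2ccc(OCCCCCCN3CCCCC3)cc12` gives 101 nM
- compound 3 `CCN(CC)CCCCCCOc1ccc2oc(-c3ccccc3)cc(=O)c2c1` gives 91 nM

Compound 3 shows the lowest number of the three, yet the steps of a 1.1-fold lower number from compound 1 to compound 3 (0.04 log units; within the scatter) and a 1.1-fold lower number from compound 2 to compound 3 (0.05 log units; within the scatter) both lie within the scatter, as does a 1.0-fold higher number from compound 1 to compound 2 (0.00 log units; within the scatter), so the three stand level in this assay.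

Compound 4 `NCCCCCCOc1ccc2oc(-c3ccccc3)cc(=O)c2c1` differs from compound 3 by amino in place of diethylamino on a saturated chain carbon, six bonds along the chain from an oxygen on an aromatic ring. The measured steps all exchange one nitrogen group for another of similar size; none strips the nitrogen down to amino alone, so they bear on this change only loosely. A weaker result is expected for compound 4, a step of a 7.7-fold higher number from compound 3 to compound 4 (0.89 log units; beyond the scatter), giving an estimate of 700 nM with a range from 150 nM to 3500 nM.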

Compound 4, half-maximal inhibitory concentration: 2100 nM
Compound 4: the middle estimate sits 3.0-fold (0.48 log units) below what was measured, within the range that was stated.
By their numbers in this assay, from the lowest: compounds 3, 1 and 2 (each within the scatter of the next); then compound 4.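

The earlier compounds shown here exchanged one carbon-bearing nitrogen group for another without a change beyond the scatter, but in this assay the bare amino group stands clearly apart from all three: diethylamino to amino (a 23-fold higher number from compound 3 to compound 4 (1.36 log units; beyond the scatter)), piperidin-1-yl to amino (a 21-fold higher number from compound 2 to compound 4 (1.32 log units; beyond the scatter)) and 4-hydroxypiperidin-1-yl to amino (a 21-fold higher number from compound 1 to compound 4 (1.32 log units; beyond the scatter)). At this chain end, then, the exchanges among these larger groups leave the number level, while the exchange for amino does not. No measurement shown accounts for the size of these steps.

On these data alone, whether a methylamino or ethylamino group would sit near compound 3 or near compound 4 remains open. So does whether these steps keep their size on a shorter or longer chain.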